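The compounds below may be only part of what the source reports. "The series", "measured", "known", "first", "only" and "open" are said of these compounds alone.

Compound 1 `O=C(O)Cn1ncc2c(Nc3ccc(NS(=O)(=O)c4ccc([N+](=O)[O-])cc4)cc3)ncnc21`: > 100 ug/mL
Compound 2 `CC(=O)Nc1ccc(Nc2ncnc3c2cnn3CC(=O)O)cc1`: > 64 ug/mL
Compound 3 `O=C(O)Cn1ncc2c(Nc3ccc(NS(=O)(=O)c4ccccc4)cc3)ncnc21`: > 100 ug/mL

All three readings in a functional assay on cells (Homo sapiens) for inhibition, read by MTT assay, with a stated time of 72 h (a lower number here means a stronger inhibitor, a higher number a weaker inhibitor), are limits and not numbers. Compound 3 stands only at a limit, > 100 ug/mL. The most common reading is the limit of > 100 ug/mL in this assay, at which 2 of the 3 values shown sit.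

Compound 4 `O=C(O)Cn1ncc2c(Nc3ccc(NS(=O)(=O)c4ccc(Br)cc4)cc3)ncnc21` differs from compound 3 by bromo in place of hydrogen on an aromatic carbon, para to a large group (bromo in place of hydrogen on an aromatic carbon).

Among the compounds with values here, two measured steps bear on this change: a step that the two limits leave unreadable from compound 1 to compound 3, and a step that the two limits leave unreadable from compound 2 to compound 3. Neither gives a size or a direction. The expected step is therefore none beyond the scatter: a number no higher from compound 3 to compound 4 (the limit leaves the size open). A reading at a limit is also expected.

Compound 4 is estimated at 100 ug/mL, with an expected range of 50 ug/mL to 200 ug/mL.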

Compound 4, half-maximal inhibitory concentration: > 64 ug/mL
Compound 4: a limit, no number (the forecaster's own chance of this, stated with the estimate: 85%); the middle value is on the limit's open side.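

Within the data shown here, compound 4 stands only at a limit, > 64 ug/mL, so no step to it from compound 1, compound 2 or compound 3 can be read in this assay. The compounds shown leave open whether hydrogen, nitro or bromo on the aromatic carbon makes any difference to inhibition.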